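Swapping the amide end of compound 3 for a furan ring

The compounds below may be only part of what the source reports. "The series", "measured", "known", "first", "only" and "open" are said of these compounds alone.

Measured compounds:
compound 1 `CCS(=O)(=O)N1CCN(c2ccc(OCC3CCN(C(=O)OC(C)C)CC3)cn2)CC1` gives 1300 nM
compound 2 `CC(C)OC(=O)N1CCC(COc2ccc(N3CCN(S(=O)(=O)CC4CCCCC4)CC3)nc2)CC1` gives 90 nM
compound 3 `CCCS(=O)(=O)N1CCN(c2ccc(OCC3CCN(C(=O)NC(C)(C)C)CC3)cn2)CC1` gives 800 nM

These three values come from a functional assay on CHO-K1 cells for agonist activity at Glucose-dependent insulinotropic receptor (Homo sapiens), read by a luciferase reporter, with a stated time of 5 h; on this read-out higher numbers stand for an effect only at larger amounts of compound and lower numbers for an effect already at smaller amounts. Compound 3 stands second highest of the three numbers. Its nearest neighbour is compound 1, whose value lies within the scatter of compound 3, so the two cannot be told apart; compound 2 lies beyond the scatter, with the clearly lower number.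

The new compound 4 `CCCS(=O)(=O)N1CCN(c2ccc(OCC3CCN(C(=O)c4ccco4)CC3)cn2)CC1` is made from compound 3 by one change: furan-2-yl in place of (tert-butyl)amino on a carbonyl carbon. Among the compounds with values here, the only measured step, a 14-fold lower number from compound 1 to compound 2 (1.16 log units; beyond the scatter), concerns a different place, a saturated chain carbon bound to a sulfonyl sulfur, and so does not bear directly on the change from (tert-butyl)carbamoyl to (furan-2-yl)carbonyl. Compound 1 and compound 3 differ at both ends of the shared core and their values lie within the scatter, which hints that this end tolerates change, but that is not a direct test.

Within the data shown here, with no precedent for this change, compound 4 is expected to stay near compound 3, and the estimated step is a 1.1-fold lower number from compound 3 to compound 4 (0.06 log units; within the scatter). In this assay compound 4 is estimated at 700 nM, with a range from 250 nM to 2000 nM.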

Compound 4, half-maximal effective concentration: 2000 nM
Compound 4: middle estimate off by 2.9-fold (0.46 log units), on the low side, within the range that was stated.
By their numbers in this assay, from the lowest: compound 2; then compounds 3, 1 and 4 (each within the scatter of the next, the first and the last beyond it).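

Within the data shown here, this is the first comparison that changes only the group on the carbonyl carbon, and in this assay it gives a 2.5-fold higher number from compound 3 to compound 4 (0.40 log units; beyond the scatter), so this position does respond to what is placed on it, though the step is modest. Both groups hold 5 heavy atoms, so the step comes with no change in that count; what differs is that furan-2-yl brings an aromatic five-membered ring and a hydrogen-bond acceptor, while (tert-butyl)amino brings a hydrogen-bond donor and no ring. No measurement here explains why the number rises, so the step stays an observation without a cause.

The single swap changes the ring, the donor and the acceptor together, so the compounds shown cannot say which of these differences matters, whereas cyclopentylamino on the same carbonyl carbon would keep a donor while adding a ring, and thiophen-2-yl would keep a five-membered aromatic ring with sulfur as its hetero atom. On these data alone, it also remains open whether cyclohexylmethyl on the sulfonyl sulfur, the group found in compound 2, would give a similar result with furan-2-yl on the carbonyl carbon.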